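The source may hold more compounds than are shown below. What is called first, only, known or untested is meant among the compounds shown, and "the series" means these compounds.

Measured so far:
- compound 1 `COc1ccc(-c2cc(=O)c3c(OC)cc(OC)cc3n2Cc2ccccc2)cc1`: > 17300 nM in a functional assay on KOPN-8 cells (Homo sapiens) for antiproliferative activity, with a stated time of 72 h; a higher number here means that more compound is needed for the effect, a lower number that less compound is needed
- compound 2 `COc1ccc(-c2c(I)c(=O)c3c(OC)cc(OC)cc3n2S(=O)(=O)c2ccc(OC)cc2)cc1`: 8580 nM
- compound 3 `COC(=O)c1cc(=O)c2c(OC)cc(OC)cc2n1S(=O)(=O)c1ccc(C)cc1`: 6000 nM.

Compound 1 is reported by this assay only as a limit, not a number; compound 1 stands at the limit of > 17300 nM in this assay, at which 1 of the 3 values shown sits. Compound 4 `COc1ccc(-c2cc(=O)c3c(OC)cc(OC)cc3n2S(=O)(=O)c2ccc(F)cc2)cc1` differs from compound 1 in one place: (4-fluorophenyl)sulfonyl in place of benzyl on an aromatic nitrogen. For the measured compounds named here, no measured pair shows this change directly. Compound 2 gives 8580 nM and compound 3 gives 6000 nM, both numbers rather than limits. The step from compound 1 to compound 4 is therefore expected to go toward less compound needed, by about an at least 2.4-fold lower number from compound 1 to compound 4 (0.39 log units; beyond the scatter). Compound 4 is estimated at 7000 nM, expected to fall between 2500 nM and 20000 nM.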

Compound 4, half-maximal effective concentration: > 65500 nM
Compound 4 gave a limit, no number; the forecaster's own chance of this, stated with the estimate: 20%; middle value at least 9.3-fold (0.97 log units) from the limit.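

In this assay, for the compounds shown here, compound 1 and compound 4 are both reported only as limits, not numbers, and no step between them can be read. The compounds shown leave open whether, and how far, (4-fluorophenyl)sulfonyl in place of benzyl on the aromatic nitrogen changes the amount of compound needed.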